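The source may report more compounds than this note shows. Statements on the series, on what has been measured and on what is new or still open speak of the compounds shown alone.

Working notes on a small set of dienone hybrids tested in a functional assay on HCT-116 cells (Homo sapiens) for inhibition, read by sulforhodamine B assay, with a stated time of 48 h, tested at 50 uM; a higher number here means more inhibition of growth at the concentration tested, a lower number less inhibition of growth.

Compound 1 `COc1cc(/C=C/C(=O)/C=C/c2cccs2)ccc1OCc1cn(CCCCCOc2cc(=O)oc3ccccc23)nn1` gives 31% in this assay. Compound 2 `COc1ccc(/C=C/C(=O)/C=C/c2ccc(OCc3cn(CCCCCOc4cc(=O)oc5ccccc45)nn3)c(OC)c2)cc1` carries the change 4-methoxyphenyl in place of thiophen-2-yl on a double-bonded chain carbon bound to a double-bonded chain carbon on the core of compound 1. In this assay compound 2 gives 35%. The resulting step is a number 4 percentage points higher from compound 1 to compound 2 (within the scatter), so the two numbers sit inside the usual scatter and no direction can be read from this pair alone.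

Compound 3 `COc1cc(/C=C/C(=O)/C=C/c2cccs2)ccc1OCc1cn(CCCCOc2cc(=O)oc3ccccc23)nn1` has a core that differs from the core of compound 1 in more than one place; the difference between the two cores is not broken down here. In this assay compound 3 gives 41%. Compared with compound 2 and compound 1, the numbers of compound 3 lie within the scatter of both, so no ranking among the three is claimed.

Compound 4 `COc1ccc(/C=C/C(=O)/C=C/c2ccc(OCc3cn(CCCCOc4cc(=O)oc5ccccc45)nn3)c(OC)c2)cc1` is not yet measured. It stands to compound 3 as compound 2 stands to compound 1: the change is 4-methoxyphenyl in place of thiophen-2-yl on a double-bonded chain carbon bound to a double-bonded chain carbon, the same change as before, at the same place, on a double-bonded chain carbon bound to a double-bonded chain carbon. For the measured compounds named here, the only precedent for this change is the single pair in which it gave a number 4 percentage points higher from compound 1 to compound 2 (within the scatter). The step from compound 3 to compound 4 is therefore expected to be a number 4 percentage points higher from compound 3 to compound 4 (within the scatter), a size taken from the earlier pair and hence no more than the scatter of this assay. On that basis compound 4 is estimated at 45% in this assay. Going by the values given here, the expected range for compound 4 runs from 31% to 59%, wide because the single precedent a number 4 percentage points higher from compound 1 to compound 2 (within the scatter) is itself within the scatter.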

Compound 4, percent growth inhibition at one concentration: 40%
For compound 4 the middle estimate is 5 percentage points above the measured one; the range from low to high includes it.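

In this assay the replacement of thiophen-2-yl by 4-methoxyphenyl, on a double-bonded chain carbon bound to a double-bonded chain carbon, gives a number 1 percentage points lower from compound 3 to compound 4 (within the scatter) on the second core. Set beside the earlier pair, the two steps do not differ: the same change on two cores in this assay, a number 4 percentage points higher (within the scatter) from compound 1 to compound 2 and a number 1 percentage points lower (within the scatter) from compound 3 to compound 4, 5 percentage points apart, within the scatter of two such steps. The change can thus be carried between these two cores without any readable shift in the result, but with both steps inside the scatter this shows neither a direction for the change nor that it is truly neutral, and two pairs tested at a single concentration on one cell line say nothing about cores beyond these two.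

The compounds shown leave open whether any group at this place would move the number beyond the scatter, since only thiophen-2-yl and 4-methoxyphenyl stand there, both with no net charge; a phenyl carrying a dimethylamino group or a carboxylic acid would test that. Also open, as far as these compounds go, is whether a result at this place would carry over to a core with a longer chain than those of compound 1 and compound 3.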